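Working notes: from compound 3 to compound 4

A few compounds are considered here, and "the series" means these few. Any claim that something is new, unique, unknown or untested is made for them only; others in the source may bear on it.

In a functional assay on HL-60 cells (Homo sapiens) for inhibition, read by MTT assay, with a stated time of 72 h (on this read-out lower numbers stand for stronger inhibition and higher numbers for weaker inhibition), compound 1 `Cc1nc(-c2ccccc2F)c(C(=O)N2CCN(c3cc(Cl)ccc3C)CC2)o1` gives 229 nM, compound 2 `COc1cccc(N2CCN(C(=O)c3oc(C)nc3-c3ccccc3F)CC2)c1` gives 56.1 nM and compound 3 `Cc1nc(-c2ccccc2F)c(C(=O)N2CCN(c3cc(Cl)cc(Cl)c3)CC2)o1` gives 60.2 nM. Compound 3 stands level with compound 2, since a 1.1-fold higher number from compound 2 to compound 3 (0.03 log units; within the scatter) lies within the scatter. Compound 1 holds the highest number, with modest steps beyond the scatter to the other two: a 4.1-fold lower number from compound 1 to compound 2 (0.61 log units; beyond the scatter) and a 3.8-fold lower number from compound 1 to compound 3 (0.58 log units; beyond the scatter).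

The next compound is compound 4 `COc1ccc(Cl)cc1N1CCN(C(=O)c2oc(C)nc2-c2ccccc2F)CC1`, where 5-chloro-2-methoxyphenyl takes the place of 3,5-dichlorophenyl on an amine nitrogen in a ring: 5-chloro-2-methoxyphenyl in place of 3,5-dichlorophenyl on an amine nitrogen in a ring. By name, the entering group is closest to the 5-chloro-2-methylphenyl of compound 1, so a 3.8-fold lower number from compound 1 to compound 3 (0.58 log units; beyond the scatter) is the step that bears most directly, read in reverse. Compound 2 also carries a methoxy group, on its 3-methoxyphenyl, and its 56.1 nM argues against a full return to the level of compound 1. Among the measured compounds shown here, no measured step exchanges methyl for methoxy within one group, so this reading remains uncertain.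

A modest rise is therefore expected in this assay, smaller than the reverse of the step to compound 3. The expected step is a 2.2-fold higher number from compound 3 to compound 4 (0.33 log units; beyond the scatter). Compound 4 is estimated at 130 nM, with an expected range of 45 nM to 380 nM.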

Compound 4, half-maximal inhibitory concentration: 153 nM
Compound 4: the middle estimate sits 1.2-fold (0.07 log units) below what was measured, and the stated range covers the measured number.
By their numbers in this assay, from the lowest: compounds 2 and 3 (each within the scatter of the next); then compounds 4 and 1 (each within the scatter of the next).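

In this assay the step (a 2.5-fold higher number from compound 3 to compound 4 (0.41 log units; beyond the scatter)) shows that 5-chloro-2-methoxyphenyl on the amine nitrogen in the ring does not hold the level of 3,5-dichlorophenyl, and the step (a 2.7-fold higher number from compound 2 to compound 4 (0.44 log units; beyond the scatter)) shows that a methoxy group on the aromatic ring does not by itself carry the level of compound 2. Among the compounds shown here, the first direct exchange of methoxy for methyl on an aromatic carbon (a 1.5-fold lower number from compound 1 to compound 4 (0.18 log units; within the scatter)) leaves compound 1 and compound 4 level, so at this position the four compounds fall into two pairs, with compound 2 and compound 3 at the lower numbers and compound 1 and compound 4 at the higher ones. No measured evidence bears on the cause of this split.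

As far as these compounds go, the pairing rests on four groups only, so it stays open where a plain phenyl, a 3-chlorophenyl or a 5-chloro-2-ethoxyphenyl would fall. Also open, from the compounds shown here alone, is whether the same pairing holds with an amine or a carboxylic acid carried on the shared core.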